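This account rests on a few compounds, and the source may have more. Where it says the series, first, only, none or still open, it means among the compounds named here.

Measured so far:
compound 1 `Cc1cc(-c2cccc(O)c2)c2ncc(CSCCc3ccccc3)n2c1` — 20 ug/mL
compound 2 `Cc1cc(-c2ccccc2)c2ncc(CSCCc3ccccc3)n2c1` — 20 ug/mL
compound 3 `Cc1cc(-c2ccccc2)cn2c(CSCCc3ccccc3)cnc12` — 20 ug/mL

All three were run in an ADME assay on HEL cells (Homo sapiens) for cytotoxicity, with a stated time of 3 days; on this read-out lower numbers stand for higher toxicity in this test and higher numbers for lower toxicity in this test. The change from compound 2 to compound 1 is hydroxy in place of hydrogen on an aromatic carbon, and it gave no change at the digits printed from compound 2 to compound 1 (within the scatter). Compound 3 carries a different core; the difference between the two cores is not broken down here, and the values of compound 2 and compound 3 show no change within the scatter.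

Compound 4 `Cc1cc(-c2ccc(O)cc2)cn2c(CSCCc3ccccc3)cnc12` is not yet measured. From compound 3 it differs by hydroxy in place of hydrogen on an aromatic carbon. This is the same kind of change as from compound 2 to compound 1, but not the same: there the hydroxy sits meta to a large group, here para to a large group. Because no change at the digits printed from compound 2 to compound 1 (within the scatter), the estimated step is no change at the digits printed from compound 3 to compound 4 (within the scatter). Compound 4 is expected at 20 ug/mL, between 10 ug/mL and 40 ug/mL.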

Compound 4, minimum cytotoxic concentration: >= 100 ug/mL
Compound 4: a limit, no number (the forecaster's own chance of this, stated with the estimate: 20%); at least 5.0-fold (0.69 log units) between middle value and limit.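

In this assay, hydroxy in place of hydrogen on an aromatic carbon does not carry over unchanged between the two cores: the same change on two cores in this assay, no change at the digits printed (within the scatter) from compound 2 to compound 1 and an at least 5.0-fold higher number (0.69 log units; beyond the scatter) from compound 3 to compound 4, at least 5.0-fold (0.69 log units) apart, beyond the scatter of two such steps

On the core of compound 3, the result is an at least 5.0-fold higher number from compound 3 to compound 4 (0.69 log units; beyond the scatter). Compound 4 gives >= 100 ug/mL, which is a limit of the assay and not a number; the two steps do not show whether the core or the place of the hydroxy, para to a large group in compound 4 but placed differently in compound 1, accounts for the gap.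

Still open, as far as these compounds go, is how hydroxy para to a large group reads on the core of compound 1. Also open, from the compounds shown here alone, is how a methoxy or an amine in that place would read on either core.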